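The source may hold more compounds than are shown below. What is called first, only, known or untested is meant among the compounds shown, and "the series" means these compounds.

Measured compounds and their values:
Compound 1, `Fc1cc(Cl)ccc1-n1c(=S)n2n(c1=S)CCCC2`, gives 23.4 nM.
Compound 2, `COC(=O)CSc1cc(-n2c(=S)n3n(c2=S)CCCC3)c(F)cc1Cl`, gives 186 nM.
Compound 3, `Fc1cc(Cl)ccc1/N=c1\sc(=S)n2n1CCCC2`, gives 120 nM.

All three were tested in a functional assay on the whole organism for inhibition, with Scenedesmus acutus as the target; on this read-out lower numbers stand for stronger inhibition and higher numbers for weaker inhibition. Compound 1 and compound 2 share the same core and differ in one place: ((methoxycarbonyl)methyl)sulfanyl in place of hydrogen on an aromatic carbon. That single change made a 7.9-fold higher number from compound 1 to compound 2 (0.90 log units; beyond the scatter), so compound 2, which carries the added group, is the weaker inhibitor of that pair. Compound 3 is built from the same atoms as compound 1, joined in a different way; the difference between the two cores is not broken down here. The number for compound 3 is higher than that for compound 1 by more than the usual scatter, while the numbers for compound 3 and compound 2 lie within the scatter of each other, so no order can be drawn between those two.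

Compound 4, `COC(=O)CSc1cc(/N=c2\sc(=S)n3n2CCCC3)c(F)cc1Cl`, has not yet been measured. It differs from compound 3 in exactly the same way that compound 2 differs from compound 1: ((methoxycarbonyl)methyl)sulfanyl in place of hydrogen on an aromatic carbon. The surroundings of the place are the same in both pairs, so this is the same change made on the other core. Going by the values given here, only one earlier example of it exists, and how far a step carries over from one core to another is unknown from these data alone. Still, the step from compound 3 to compound 4 in this assay is expected to be about as large as the earlier one, that is a 7.1-fold higher number from compound 3 to compound 4 (0.85 log units; beyond the scatter), because the earlier change gave a 7.9-fold higher number from compound 1 to compound 2 (0.90 log units; beyond the scatter). Compound 4 is therefore estimated at 850 nM, expected to fall between 300 nM and 2500 nM.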

Compound 4, half-maximal inhibitory concentration: 245 nM
Beside the measured number, compound 4's estimate is 3.5-fold (0.54 log units) above it, outside the stated range (below it).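

In this assay, adding the ((methoxycarbonyl)methyl)sulfanyl group to the core of compound 3 again weakened inhibition, giving a 2.0-fold higher number from compound 3 to compound 4 (0.31 log units; beyond the scatter), so the direction of the change carried over from one core to the other. The size of the step did not carry over, and the gap between the two steps is larger than ordinary repeat variation would account for: the same change on two cores in this assay, a 7.9-fold higher number (0.90 log units; beyond the scatter) from compound 1 to compound 2 and a 2.0-fold higher number (0.31 log units; beyond the scatter) from compound 3 to compound 4, 3.9-fold (0.59 log units) apart, beyond the scatter of two such steps These two pairs show that, in this series, a step measured on one core cannot simply be transferred at full size to the other, but they do not explain why the cores respond differently, and two examples give no rule for predicting the step on any further core.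

The compounds shown leave open how much of each step comes from the sulfur link, the methylene chain or the methyl ester, since the whole group enters as one piece. On these data alone, it also remains open whether the two cores would diverge in the same way with a different group on that aromatic carbon, such as a carboxylic acid, an amine or a longer chain.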